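This account rests on a few compounds, and the source may have more. Where it says the series, first, only, none or still open, it means among the compounds named here.

Measured so far in an ADME assay on MRC5 cells (Homo sapiens), read by MTT assay, with a stated time of 72 h; a lower number here means a stronger inhibitor, a higher number a weaker inhibitor:

Compound 1 `Nc1nc2c(c(-c3ccco3)cn2[C@@H]2O[C@H](CO)[C@@H](O)[C@H]2O)c(=O)[nH]1`; compound 1 gives > 100000 nM, a limit of the assay.
Compound 2 `Nc1nc2c(c(-c3cc4ccccc4o3)cn2[C@@H]2O[C@H](CO)[C@@H](O)[C@H]2O)c(=O)[nH]1`; compound 2 gives > 100000 nM, a limit of the assay.
Compound 3 `Nc1nc(N)c2c(-c3cc4ccccc4o3)cn([C@@H]3O[C@H](CO)[C@@H](O)[C@H]3O)c2n1`; compound 3 gives 78500 nM.

Compound 3 is the only one of the three to return a number in this assay; the other two sit at the limit of > 100000 nM in this assay, at which 2 of the 3 values shown sit. The change from compound 2 to compound 1 is furan-2-yl in place of 1-benzofuran-2-yl on an aromatic carbon. Its step, a step that the two limits leave unreadable from compound 2 to compound 1, cannot be read in size, as both ends are limits. The cores of compound 2 and compound 3 differ in more than one place, and that difference is not broken down here.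

Compound 4 `Nc1nc(N)c2c(-c3ccco3)cn([C@@H]3O[C@H](CO)[C@@H](O)[C@H]3O)c2n1` is not yet measured. It stands to compound 3 as compound 1 stands to compound 2: furan-2-yl in place of 1-benzofuran-2-yl on an aromatic carbon. The place is described in the same words for both pairs, so this is the same change, made a second time on the core of compound 3.

What to expect from compound 4 rests on two things. The earlier step gave no readable size, so it neither supports nor rules out a shift. Compound 3 itself gives 78500 nM, a weak result, so even a modest loss would leave compound 4 where no number can be read. Compound 4 is therefore estimated at 90000 nM, expected between 40000 nM and 200000 nM, with an expected step of a 1.1-fold higher number from compound 3 to compound 4 (0.06 log units; within the scatter), and a fair chance that only a limit is reported.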

Compound 4, half-maximal inhibitory concentration: > 100000 nM
Compound 4 was reported as a limit; the forecaster's own chance of this, stated with the estimate: 50%; middle value at least 1.1-fold (0.04 log units) from the limit.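

In this assay, going by these compounds alone, furan-2-yl in place of 1-benzofuran-2-yl gives an at least 1.2-fold higher number from compound 3 to compound 4 (0.10 log units; that floor lies within the scatter), and only this floor of the step is known, so the true size of the change on this core stays unread. Compound 4 gives > 100000 nM, a limit of the assay. The same change on the core of compound 2 cannot be read in size, so the two steps cannot be set side by side, and nothing here shows whether the change carries the same size from one core to the other; what can be said is only that the readings of this small set gather at one limit: the limit of > 100000 nM in this assay, at which 3 of the 4 values shown sit.

The compounds shown carry only furan-2-yl and 1-benzofuran-2-yl on this aromatic carbon, which leaves open how far the read-out in this assay responds to the group at this place on either core. An amine, a carboxylic acid or a longer alkyl chain on the same carbon would show whether any group there moves the series to values that can be read on both cores, and so whether a step can be compared between them.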